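This account rests on a few compounds, and the source may have more. Where it says the series, first, only, none or still open, it means among the compounds named here.

Measured in a functional assay on MDA-MB-231 cells (Homo sapiens) for antiproliferative activity, read by MTT assay, with a stated time of 72 h; on this read-out lower numbers stand for stronger inhibition and higher numbers for weaker inhibition:
Compound 1 `O=C(NO)c1ccc(NCCOc2ccc3cc2COC/C=C/COCc2cccc(c2)-c2ccnc(n2)N3)cc1`: 8690 nM
Compound 2 `O=C(O)CCCCCOc1ccc2cc1COC/C=C/COCc1cccc(c1)-c1ccnc(n1)N2`: 19900 nM

Of these two numbers, the lower belongs to compound 1. Going by the values given here, the only measured step is a 2.3-fold higher number from compound 1 to compound 2 (0.36 log units; beyond the scatter), which is modest and beyond the scatter. It places 3-carboxypropyl where (4-(hydroxycarbamoyl)phenyl)amino stood.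

Compound 3 `O=C(CCCCCOc1ccc2cc1COC/C=C/COCc1cccc(c1)-c1ccnc(n1)N2)NO` has not yet been measured. Its difference from compound 1 is 3-(hydroxycarbamoyl)propyl in place of (4-(hydroxycarbamoyl)phenyl)amino on a saturated chain carbon, two bonds along the chain from an oxygen on an aromatic ring. In words, 3-(hydroxycarbamoyl)propyl stands in place of (4-(hydroxycarbamoyl)phenyl)amino, on a saturated chain carbon, two bonds along the chain from an oxygen on an aromatic ring. Compound 3 therefore shares the hydroxycarbamoyl group with compound 1 and the propyl chain with compound 2.

Among the compounds with values here, the single measured step changes both features at once, so it bears on this change only in part and cannot separate their contributions. A modest move towards a lower number is nevertheless expected in this assay, with wide uncertainty in both directions. The expected step is a 2.2-fold lower number from compound 1 to compound 3 (0.34 log units; beyond the scatter). For compound 3 the estimate is 4000 nM, with an expected range from 1200 nM to 13000 nM.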

Compound 3, half-maximal inhibitory concentration: 8070 nM
The estimate for compound 3 lay 2.0-fold (0.30 log units) below the measured number; low and high end bracket the measured number.
By their numbers in this assay, from the lowest: compounds 3 and 1 (each within the scatter of the next); then compound 2.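

In this assay, with the hydroxycarbamoyl group kept, the exchange of (4-(hydroxycarbamoyl)phenyl)amino for 3-(hydroxycarbamoyl)propyl on a saturated chain carbon, two bonds along the chain from an oxygen on an aromatic ring, gives a 1.1-fold lower number from compound 1 to compound 3 (0.03 log units; within the scatter) and so leaves the two compounds indistinguishable, although the aromatic ring leaves with the old group and the entering group has no ring. With the chain held constant, hydroxyamino in place of hydroxy on a carbonyl carbon gives a 2.5-fold lower number from compound 2 to compound 3 (0.39 log units; beyond the scatter), a step that isolates the end group, so among these three compounds the gap beyond the scatter follows the change from carboxylic acid to hydroxamic acid and not the change of linking group. The data contain no measurement that gives a cause for either step.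

As far as these compounds go, how a longer chain ending in the same hydroxycarbamoyl group would read in this assay remains open, as does the reading of a primary amide at the chain end. From the compounds shown here alone, it is equally open whether a carboxylic acid on the (4-(hydroxycarbamoyl)phenyl)amino scaffold, in place of its hydroxycarbamoyl group, would give a step of similar size.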